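Fluorophenyl to benzyl on the ring nitrogen of compound 1

The source may report more compounds than this note shows. Statements on the series, on what has been measured and on what is new or still open speak of the compounds shown alone.

Compound 1 `CCCCCCc1cc2cn(Cc3cn(-c4ccccc4F)nn3)c(=O)nc2o1` stands at a limit of a functional assay on A549 cells (Homo sapiens) for antiproliferative activity, read by MTT assay, with a stated time of 72 h (a higher number here means a weaker inhibitor, a lower number a stronger inhibitor), giving only > 100000 nM. Compound 2 `O=c1nc2oc(CCCCl)cc2cn1Cc1cn(-c2ccccc2F)nn1` gives 69800 nM in this assay, and the step of an at least 1.4-fold lower number from compound 1 to compound 2 (0.15 log units; that floor lies within the scatter). Compound 3 `CCCCCCC#Cc1c(CCCCCC)oc2nc(=O)n(Cc3cn(-c4ccc(F)cc4)nn3)cc12` also rests at a limit in this assay, > 100000 nM. Most of the values here sit at the limit of > 100000 nM in this assay, at which 2 of the 3 values shown sit. Compound 4 `CCCCCCc1cc2cn(Cc3cn(Cc4ccccc4)nn3)c(=O)nc2o1` differs from compound 1 by benzyl in place of 2-fluorophenyl on an aromatic nitrogen. Among the compounds with values here, no measured step touches the aromatic nitrogen where this change sits; the single measured step, from compound 1 to compound 2, concerns the saturated chain and is within the scatter. Since compound 1 gives only > 100000 nM, no shift beyond the scatter is expected. Compound 4 is expected to give 100000 nM, within 50000 nM to 300000 nM, in this assay. This estimate means a step of a number no higher from compound 1 to compound 4 (the limit leaves the size open).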

Compound 4, half-maximal inhibitory concentration: 51000 nM
The estimate for compound 4 lay 2.0-fold (0.29 log units) above the measured number; the range from low to high includes it.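

Compound 1 gives > 100000 nM in this assay and that value is a limit. Within the data shown here, the first change on this aromatic nitrogen, benzyl in place of 2-fluorophenyl, gives an at least 1.9-fold lower number from compound 1 to compound 4 (0.29 log units; that floor lies within the scatter) and so shows a measured number at this place, with no shift beyond the scatter established. Going by these compounds, the size of the change stays open at this ceiling: the limit of > 100000 nM in this assay, at which 2 of the 4 values shown sit.

Open, on these data alone, is how a phenethyl group, a carboxylic acid or an amine on this aromatic nitrogen would read out. Also open, as far as these compounds go, is whether benzyl behaves alike with the chloro-bearing chain of compound 2.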